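The source may report more compounds than this note shows. Statements on the series, on what has been measured and on what is new or still open speak of the compounds shown alone.

Measured so far in a functional assay on BJAB cells (Homo sapiens) for antiproliferative activity, with a stated time of 4 days; on this read-out lower numbers stand for an effect already at smaller amounts and higher numbers for an effect only at larger amounts of compound:
- compound 1, `Cc1nn(-c2nc(-c3ccc(Cl)c(Cl)c3)c(SC(C)C)s2)c(C(=O)O)c1-c1cncnc1`: 22000 nM
- compound 2, `CC(=O)Nc1ccc(-c2c(C)nn(-c3nc(-c4ccc(Cl)c(Cl)c4)c(SC(C)C)s3)c2C(=O)O)cc1`: 139000 nM

Within the data shown here, compound 2 gives the highest of the two numbers seen so far in this assay; its nearest neighbour is compound 1, and the one step recorded, a 6.3-fold higher number from compound 1 to compound 2 (0.80 log units; beyond the scatter), is a modest one, beyond the scatter.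

Compound 3, `Cc1nn(-c2nc(-c3ccc(Cl)c(Cl)c3)c(SC(C)C)s2)c(C(=O)O)c1-c1ccncc1`, is the next member. Against compound 2 it differs in one place: pyridin-4-yl in place of 4-acetamidophenyl on an aromatic carbon. Among the measured compounds shown here, the only measured step that bears on this exchange is the one from compound 1 to compound 2, in which a six-membered ring carrying two ring nitrogens was traded for the 4-acetamidophenyl group and the number rose. The change to compound 3 moves in the opposite sense, from 4-acetamidophenyl back to a small six-membered ring with one ring nitrogen, so a lower number is expected, of a size comparable to the recorded step.

For compound 3 the expected result in this assay is 25000 nM, with a range of 8000 nM to 80000 nM, which means an estimated step of a 5.6-fold lower number from compound 2 to compound 3 (0.75 log units; beyond the scatter).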

Compound 3, half-maximal effective concentration: 5900 nM
Compound 3: the middle estimate sits 4.2-fold (0.63 log units) above what was measured; the measured number lies below the stated range.
By their numbers in this assay, from the lowest: compound 3; then compound 1; then compound 2.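

In this assay, the aromatic carbon next to the ring atom that bears a carboxy group proves more sensitive than the earlier pair suggested: replacing 4-acetamidophenyl with pyridin-4-yl gives a 24-fold lower number from compound 2 to compound 3 (1.37 log units; beyond the scatter), and this large step sets the larger group, with its 10 heavy atoms, well apart from the 6-atom ring. Size alone does not settle the outcome, since two small six-membered aromatic rings also separate, with a 3.7-fold lower number from compound 1 to compound 3 (0.57 log units; beyond the scatter), so the response at this position depends on the identity of the ring and not only on its bulk. Nothing available accounts for either step.

A plain phenyl or a pyridin-3-yl at this carbon would show whether the lower number of compound 3 goes with its ring nitrogen, and with that nitrogen's place in the ring. A 4-aminophenyl would test whether the higher number of compound 2 goes with the acetyl part of its substituent or with the substituted phenyl ring itself.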